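The source may hold more compounds than are shown below. What is called first, only, known or untested is meant among the compounds shown, and "the series" means these compounds.

Three compounds have so far been measured in a functional assay on ACHN cells (Homo sapiens) for cytotoxicity, read by sulforhodamine B assay, with a stated time of 72 h; a lower number here means a stronger inhibitor of growth, a higher number a weaker inhibitor of growth:

compound 1, `O=C(Nc1ccccc1C(F)(F)F)C1CCc2ccccc2N1C(=O)c1ccccc1`, gives 8090 nM
compound 2, `O=C(Nc1cc(C(F)(F)F)cc(C(F)(F)F)c1)C1CCc2ccccc2N1C(=O)c1ccc(Cl)cc1`, gives 2570 nM
compound 3, `O=C(Nc1ccccc1O)C1CCc2ccccc2N1C(=O)c1ccccc1`, gives 4260 nM

Compound 1 stands with the highest number of the three. Its nearest neighbour is compound 3, and the step of a 1.9-fold lower number from compound 1 to compound 3 (0.28 log units; within the scatter) lies within the scatter. The gap from compound 1 to compound 2 lies beyond the scatter, but compound 2 differs from compound 1 in two places at once, so its value alone cannot be tied to either change.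

Compound 4, `CC(=O)N1c2ccccc2CCC1C(=O)Nc1ccccc1C(F)(F)F`, differs from compound 1 in one place: methyl in place of phenyl on a carbonyl carbon. Cut one bond further out, the change reads benzoyl to acetyl, sitting on a carbonyl carbon whose other neighbours are an amide-type nitrogen in a ring. Within the data shown here, none of the measured steps touches this carbonyl; the only single-point step, from compound 1 to compound 3, alters the aromatic carbon bearing trifluoromethyl, and it stayed within the scatter. There is thus no measured guide for the present change, and the expectation is a step of modest size, leaning towards a higher number, but with wide uncertainty.

Compound 4 is therefore estimated at 12000 nM, in a range from 4000 nM to 40000 nM, which would mean an expected step of a 1.5-fold higher number from compound 1 to compound 4 (0.17 log units; within the scatter).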

Compound 4, concentration for 50% growth inhibition: > 80000 nM
Compound 4: no number, only a limit; the forecaster's own chance of this, stated with the estimate: 20%; middle value at least 6.6-fold (0.82 log units) away from the limit.
By their numbers in this assay, from the lowest: compounds 2, 3 and 1 (each within the scatter of the next, the first and the last beyond it). At a limit, above all of these: compound 4.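

In this assay compound 4 gives > 80000 nM, which is a limit of the assay and not a number: the limit of > 80000 nM in this assay, at which 1 of the 4 values shown sits. Methyl in place of phenyl on the carbonyl carbon gives an at least 9.8-fold higher number from compound 1 to compound 4 (0.99 log units; beyond the scatter), and this is the first single change shown that goes beyond the scatter, whereas the change on the aromatic carbon bearing trifluoromethyl gave a 1.9-fold lower number from compound 1 to compound 3 (0.28 log units; within the scatter). Among these compounds, the phenyl on this carbonyl therefore counts for growth inhibition in compound 1, though the limit fixes only one end of the step and leaves its full size unknown.

The compounds shown leave open whether the aromatic ring itself is needed or whether another group on this carbonyl, such as cyclohexyl, a longer chain such as butyl, or pyridyl, would serve in its place. As far as these compounds go, how an amine or a carboxylic acid on that phenyl would behave also stays open, and compound 2, which carries chloro on the benzoyl ring, differs from compound 1 in two places at once and cannot settle the question.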